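The source may report more compounds than this note shows. Statements on the series, on what has been measured and on what is new or still open speak of the compounds shown alone.

Compounds measured so far:
compound 1, `O=C(c1ccc(OC(F)(F)F)cc1)N1CCC(N(C2CC2)S(=O)(=O)c2cccc(C(F)(F)F)c2)CC1`, 300 nM
compound 2, `CS(=O)(=O)c1ccccc1C(=O)N1CCC(N(C2CC2)S(=O)(=O)c2cccc(C(F)(F)F)c2)CC1`, 660 nM

Both were tested in an assay on HEK293 cells for inhibition of Voltage-dependent N-type calcium channel subunit alpha-1B (Homo sapiens), read by FLIPR and calcium flux, in the presence of a further agent that is not named here; a lower number here means a stronger inhibitor, a higher number a weaker inhibitor. Compound 1 gives 300 nM, the lowest of the two numbers, and its nearest neighbour is compound 2 at 660 nM. The step of a 2.2-fold higher number from compound 1 to compound 2 (0.34 log units; beyond the scatter) is the only one available, and it already concerns the same place: the aromatic group attached to the carbonyl carbon.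

Compound 3, `CN(C)c1cccc(C(=O)N2CCC(N(C3CC3)S(=O)(=O)c3cccc(C(F)(F)F)c3)CC2)c1`, is not yet measured. Compared with compound 1 it differs in one place: 3-(dimethylamino)phenyl in place of 4-(trifluoromethoxy)phenyl on a carbonyl carbon. Among the compounds with values here, this is a different group from the one that enters in compound 2, so the single known step gives only a rough guide. It shows that swapping the aromatic group on that carbonyl carbon can shift the number modestly without a large loss. A step of similar size in the weakening direction, or no step beyond the scatter, is therefore expected for a 1.7-fold higher number from compound 1 to compound 3 (0.22 log units; within the scatter). Compound 3 is estimated at 500 nM, with a range from 200 nM to 1500 nM in this assay.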

Compound 3, half-maximal inhibitory concentration: 240 nM
Beside the measured number, compound 3's estimate is 2.1-fold (0.32 log units) above it, within the range that was stated.
By their numbers in this assay, from the lowest: compounds 3 and 1 (each within the scatter of the next); then compound 2.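

In this assay, putting 3-(dimethylamino)phenyl in place of 4-(trifluoromethoxy)phenyl on the carbonyl carbon gives a 1.3-fold lower number from compound 1 to compound 3 (0.10 log units; within the scatter), so this position accepts two quite different substituted phenyl groups with no change that can be told from the scatter. Putting the same group in place of 2-(methylsulfonyl)phenyl gives a 2.8-fold lower number from compound 2 to compound 3 (0.44 log units; beyond the scatter), so among these three compounds only the group in compound 2 stands apart, and only by a modest margin. Nothing measured alongside these numbers speaks to why the groups compare as they do.

The compounds shown leave open how much of the result depends on the dimethylamino group itself and how much on where it stands, a question that 4-(dimethylamino)phenyl on the same carbonyl carbon would address. On these data alone, all three groups here are substituted phenyl rings, and how a cyclohexyl group or a phenyl ring carrying a carboxylic acid would fare at this position also remains open.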